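The source may hold more compounds than are shown below. What is called first, only, known or untested is meant among the compounds shown, and "the series" means these compounds.

Measured compounds in an ADME assay on Vero cells (Chlorocebus sabaeus) for cytotoxicity, read by microscopy, with a stated time of 6 days; on this read-out higher numbers stand for lower toxicity in this test and lower numbers for higher toxicity in this test:
Compound 1, `CCCCCNc1nccnc1C(=O)NCc1ccccc1`, gives > 100000 nM, which is a limit of the assay rather than a number.
Compound 2, `CCCCNc1nccnc1C(=O)NCc1ccccc1`, gives > 100000 nM, also a limit of the assay.
Compound 3, `CCCCCCCCNc1nccnc1C(=O)NCc1ccccc1`, gives > 100000 nM, again a limit of the assay.

Compound 3 therefore stands only at a limit in this assay, and the two other values sit at the same limit, as the limit of > 100000 nM in this assay, at which 3 of the 3 values shown sit, records. The steps a step that the two limits leave unreadable from compound 1 to compound 2, a step that the two limits leave unreadable from compound 1 to compound 3 and a step that the two limits leave unreadable from compound 2 to compound 3 are for that reason unreadable: two limits leave no distance to compare. Compound 4, `CCCCCCCNc1nccnc1C(=O)NCc1ccccc1`, differs from compound 3 by hydrogen in place of methyl on a saturated chain carbon, seven bonds along the chain from a nitrogen on an aromatic ring; a methyl leaves and a hydrogen enters on the same chain that the three measured steps lengthen or shorten. Those steps bear on the change only in that none of them produced a readable number, so no direction and no size beyond the scatter can be drawn from them. The step of a number no higher from compound 3 to compound 4 (the limit leaves the size open) is expected to stay within the scatter. Compound 4 is thus estimated at 100000 nM in this assay, in a range from 50000 nM to 200000 nM, most likely reported again as a limit.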

Compound 4, minimum cytotoxic concentration: > 100000 nM
Compound 4: no number, only a limit; the forecaster's own chance of this, stated with the estimate: 85%; the middle value sits exactly at the limit.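

Among these compounds, no step to compound 4 can be read, since compound 1, compound 2, compound 3 and compound 4 all stop at one limit in this assay: the limit of > 100000 nM in this assay, at which 4 of the 4 values shown sit. The compounds shown leave open at what concentration any of them would become toxic to the cells, and whether chain length changes that.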